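Triazole Substituent Swap on a Quinoline Core: Cytotoxicity Outlook

The source may hold more compounds than are shown below. What is called first, only, known or untested is meant among the compounds shown, and "the series" means these compounds.

Three compounds share one core and differ only in the group on the triazole ring. Compound 1 `COc1nc2ccc(Br)cc2cc1C(c1ccccc1)n1cc(C2CC2)nn1` gives 21.8% in an ADME assay on PANC-1 cells (Homo sapiens) for cytotoxicity, read by sulforhodamine B assay, with a stated time of 48 h, tested at 10 uM; on this read-out higher numbers stand for more inhibition at the one concentration tested (going by the name of the read-out) and lower numbers for less inhibition. Compound 2 `COc1nc2ccc(Br)cc2cc1C(c1ccccc1)n1cc(-c2ccc(Br)cc2)nn1` gives 10.4% in this assay, and compound 3 `CCCCCCCc1cn(C(c2ccccc2)c2cc3cc(Br)ccc3nc2OC)nn1` gives 16.6%. Compound 3 thus holds the second highest of the three numbers: a number 5.2 percentage points lower from compound 1 to compound 3 (within the scatter), and a number 6.2 percentage points higher from compound 2 to compound 3 (within the scatter), so both of its neighbours sit within the scatter of it.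

Compound 4 `COc1nc2ccc(Br)cc2cc1C(c1ccccc1)n1cc(-c2ccc(OC(F)(F)F)cc2)nn1` differs from compound 3 in a single place: 4-(trifluoromethoxy)phenyl in place of heptyl on an aromatic carbon. For the measured compounds named here, two measured steps bear on this. The closest is a number 6.2 percentage points higher from compound 2 to compound 3 (within the scatter), which compares the 4-bromophenyl of compound 2 with the heptyl of compound 3 and falls within the scatter. Going by the values given here, the other is a number 11.4 percentage points lower from compound 1 to compound 2 (beyond the scatter), the only step of this set that lies beyond the scatter, and it goes downward when 4-bromophenyl enters. On that basis the step to compound 4 is expected to be small and downward, one that may well stay inside the scatter, and the expected size is a number 5.6 percentage points lower from compound 3 to compound 4 (within the scatter).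

Compound 4 is therefore estimated to give 11% in this assay, within a range of 2% to 22%.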

Compound 4, a percentage reported as inhibition, at one concentration (the size of the read-out at that concentration, not a potency): 11.7%
Estimate against measurement, compound 4: 0.7 percentage points below, within the range that was stated.
By their numbers in this assay, from the lowest: compounds 2, 4, 3 and 1 (each within the scatter of the next, the first and the last beyond it).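

In this assay, 4-(trifluoromethoxy)phenyl in place of heptyl gives a number 4.9 percentage points lower from compound 3 to compound 4 (within the scatter), so at this carbon of the triazole ring, next to the ring nitrogen, this aromatic group cannot be told apart from the open heptyl chain. Trifluoromethoxy in place of bromo on the phenyl ring gives a number 1.3 percentage points higher from compound 2 to compound 4 (within the scatter), the first comparison of two groups on that ring, and the exchange leaves no difference that can be read. The step of a number 10.1 percentage points lower from compound 1 to compound 4 (beyond the scatter) repeats the earlier step of a number 11.4 percentage points lower from compound 1 to compound 2 (beyond the scatter), so cyclopropyl now stands apart from two substituted phenyl groups rather than one, although heptyl goes against a clean split, since the step of a number 5.2 percentage points lower from compound 1 to compound 3 (within the scatter) stays within the scatter and compound 3 also lies within the scatter of compound 2 and compound 4.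

Nothing available here accounts for these differences or for their absence. As far as these compounds go, it remains open whether a phenyl ring bearing an amine or a carboxylic acid, or a chain ending in a hydroxyl group, would give a number beyond the scatter of these four compounds.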